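Adding a Dimethylamino Group to the Five-Membered Ring

A few compounds are considered here, and "the series" means these few. Any claim that something is new, unique, unknown or untested is made for them only; others in the source may bear on it.

Of the compounds shown here, three have been measured in a functional assay (aorta) for inhibition, with Rattus norvegicus as the target; on this read-out higher numbers stand for weaker inhibition and lower numbers for stronger inhibition. Compound 1 `CCc1nsc(-c2ccc(N3CCN(c4cccc(C(F)(F)F)c4)CC3)nn2)n1` gives 8 nM. Compound 2 `CN(C)c1nsc(-c2ccc(N3CCN(c4cccc(C(F)(F)F)c4)CC3)nn2)n1`, which carries a dimethylamino group on its five-membered ring, gives 0.4 nM; 6 nM (2 entries). Compound 3 `FC(F)(F)c1cccc(N2CCN(C3CCN(c4ccc(-c5ncns5)nn4)CC3)CC2)c1`, which has a hydrogen at that position and a longer linker between the shared core and the trifluoromethyl-bearing ring, gives 0.3 nM. Among the compounds with a single number, compound 3 has the lowest one, and its distance from compound 1 lies beyond the usual scatter of repeated measurements.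

Compound 4 `CN(C)c1nsc(-c2ccc(N3CCC(N4CCN(c5cccc(C(F)(F)F)c5)CC4)CC3)nn2)n1` has not yet been measured. It differs from compound 3 by dimethylamino in place of hydrogen on an aromatic carbon. Among the measured compounds shown here, no pair of measured compounds shows exactly this change alone, so its effect can only be judged from what the measured compounds suggest. Compound 2, which carries the same dimethylamino group, shows the spread (the several entries of compound 2 in this assay, 0.4 nM; 6 nM (2 entries)), which reaches down to a number close to that of compound 3.

Compound 4 is therefore expected to give about 0.5 nM, with a likely range from 0.1 nM to 3 nM. This estimate corresponds to a step of a 1.7-fold higher number from compound 3 to compound 4 (0.22 log units; within the scatter), expected to stay within the scatter rather than to move the number in a clear direction.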

Compound 4, half-maximal inhibitory concentration: < 1 nM
Compound 4: no number, only a limit (the forecaster's own chance of this, stated with the estimate: 5%); the middle value lies beyond the limit too.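

In this assay compound 4 gives < 1 nM, which is a limit of the assay and not a number, so the step from compound 3 to compound 4 cannot be read. The compounds shown leave open whether dimethylamino in place of hydrogen on this aromatic carbon changes the number at all, and in which direction.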